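Amide variation on a dihydroxyheptanoic acid pyrazole series

The source may report more compounds than this note shows. Statements on the series, on what has been measured and on what is new or still open speak of the compounds shown alone.

Measured so far: compound 1 `CC(C)c1c(C(=O)N(C)Cc2ccccc2)nn(-c2ccc(F)cc2)c1CC[C@@H](O)C[C@@H](O)CC(=O)O` gives 2870 nM in a functional assay on L6 cells (Rattus norvegicus) for inhibition; a lower number here means a stronger inhibitor, a higher number a weaker inhibitor; compound 2 `Cc1ccc(CNC(=O)c2nn(-c3ccc(F)cc3)c(CC[C@@H](O)C[C@@H](O)CC(=O)O)c2C(C)C)cc1` gives 800 nM; compound 3 `CC(C)c1c(C(=O)N2CCCCC2)nn(-c2ccc(F)cc2)c1OC[C@@H](O)C[C@@H](O)CC(=O)O` gives 32200 nM.

Compound 3 stands highest of the three numbers, with compound 1 nearest and compound 2 furthest, both steps beyond the scatter. Compound 4 `CC(C)c1c(C(=O)N(C)Cc2ccc(F)cc2)nn(-c2ccc(F)cc2)c1OC[C@@H](O)C[C@@H](O)CC(=O)O` is not yet measured. It differs from compound 3 only at the amide: (4-fluorobenzyl)(methyl)amino in place of piperidin-1-yl on a carbonyl carbon.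

For the measured compounds named here, no measured step changes exactly this group. Going by the values given here, the one step that bears on the amide is a 3.6-fold lower number from compound 1 to compound 2 (0.55 log units; beyond the scatter), a modest shift for a change at the same carbonyl. Among the compounds with values here, compound 1 carries a benzyl(methyl)amino group at that carbonyl, as compound 4 does with a fluorine added, and its number is well below that of compound 3, though the two also differ elsewhere and no single step links them. A lower number than compound 3 is therefore expected for compound 4, as a 4.6-fold lower number from compound 3 to compound 4 (0.66 log units; beyond the scatter). The estimate for compound 4 in this assay is 7000 nM, expected to lie between 2000 nM and 25000 nM.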

Compound 4, half-maximal inhibitory concentration: 2800 nM
The estimate for compound 4 lay 2.5-fold (0.40 log units) above the measured number, and the stated range covers the measured number.
By their numbers in this assay, from the lowest: compound 2; then compounds 4 and 1 (each within the scatter of the next); then compound 3.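

In this assay, (4-fluorobenzyl)(methyl)amino in place of piperidin-1-yl on a carbonyl carbon gives a 12-fold lower number from compound 3 to compound 4 (1.06 log units; beyond the scatter) and so shows that the amide group alone can move the number by a large step on the core of compound 3. For the compounds shown here, the only earlier step at this carbonyl, a 3.6-fold lower number from compound 1 to compound 2 (0.55 log units; beyond the scatter) on a different core, was modest, so the position now appears more sensitive than that step suggested, at least for this pair. No measurement shown gives a reason for the size of this step.

The compounds shown leave open whether the fluorine, the methyl on the amide nitrogen or the benzyl group accounts for the step on this core. Also open, on these data alone, is where a small open-chain amide such as dimethylamino, or a pyrrolidin-1-yl ring, would fall relative to compound 3 and compound 4.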